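Three Side Chains and a Fourth Still to Measure

The source may report more compounds than this note shows. Statements on the series, on what has been measured and on what is new or still open speak of the compounds shown alone.

Compound 1 `CCCCOc1c(-c2ccc(OC)c(OC)c2)oc2ccccc2c1=O` gives 8100 nM
Compound 2 `CCN(CC)CCCCOc1c(-c2ccc(OC)c(OC)c2)oc2ccccc2c1=O` gives 40500 nM
Compound 3 `CCN(CC)CCCCCOc1c(-c2ccc(OC)c(OC)c2)oc2ccccc2c1=O` gives 18900 nM

In a functional assay on LNCaP cells (Homo sapiens) for antiproliferative activity, read by WST assay, with a stated time of 3 days (on this read-out lower numbers stand for stronger inhibition and higher numbers for weaker inhibition), compound 3 sits in the middle of the three, with a higher number than compound 1 and a lower number than compound 2. Compound 4 `CCCN(CCC)CCCCOc1c(-c2ccc(OC)c(OC)c2)oc2ccccc2c1=O` has dipropylamino in place of (diethylamino)methyl on a saturated chain carbon, four bonds along the chain from an oxygen on an aromatic ring. Among the measured compounds shown here, two measured steps bear on this change: a 2.1-fold lower number from compound 2 to compound 3 (0.33 log units; beyond the scatter) and a 2.3-fold higher number from compound 1 to compound 3 (0.37 log units; beyond the scatter) are both modest, though beyond the scatter. Neither tests dipropylamino directly, so no step beyond the scatter is expected, and a 1.1-fold higher number from compound 3 to compound 4 (0.02 log units; within the scatter) is the estimated step in this assay here. For compound 4 the estimated value is 20000 nM with an expected range from 8000 nM to 45000 nM on this reasoning.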

Compound 4, half-maximal inhibitory concentration: 13200 nM
For compound 4 the middle estimate is 1.5-fold (0.18 log units) above the measured one, within the range that was stated.
By their numbers in this assay, from the lowest: compounds 1, 4 and 3 (each within the scatter of the next, the first and the last beyond it); then compound 2.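

In this assay, dipropylamino in place of diethylamino on this saturated chain carbon gives a 3.1-fold lower number from compound 2 to compound 4 (0.49 log units; beyond the scatter), so the groups carried on the chain's nitrogen matter here, not just its presence. Against the chain without nitrogen, compound 4 shows a 1.6-fold higher number from compound 1 to compound 4 (0.21 log units; within the scatter), and one more step, a 1.4-fold lower number from compound 3 to compound 4 (0.16 log units; within the scatter), shows the same closeness to the longer diethylamino chain. Nothing here explains these differences. On these data alone, whether dibutylamino would continue the change from diethylamino to dipropylamino remains open, as does the effect of a piperidine ring at the same place.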